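This account rests on a few compounds, and the source may have more. Where it says the series, first, only, none or still open, it means among the compounds named here.

Working notes on the series. In an ADME assay on Vero cells (Chlorocebus sabaeus) for cytotoxicity, read by MTT assay, with a stated time of 72 h (a lower number here means that less compound is tolerated, a higher number that more compound is tolerated), compound 2 `COC(=O)c1cc(-c2cccc(NC(=O)c3ccc(/C=C/C(=O)c4ccc(F)cc4F)cc3)c2)on1` gives > 40 ug/mL, which is a limit of the assay and not a number. Compound 1 `CCCOc1ccc(C(=O)/C=C/c2ccc(C(=O)Nc3cccc(-c4cc(C(=O)OC)no4)c3)cc2)cc1` gives > 40 ug/mL in this assay, likewise a limit. The step that the two limits leave unreadable from compound 1 to compound 2 therefore stays unreadable between the two limits. For the measured compounds named here, the only evidence available is the limit of > 40 ug/mL in this assay, at which 2 of the 2 values shown sit. Compound 3 `COC(=O)c1cc(-c2cccc(NC(=O)c3ccc(/C=C/C(=O)c4ccccc4Cl)cc3)c2)on1` is not yet measured in this assay; it differs from compound 2 by 2-chlorophenyl in place of 2,4-difluorophenyl on a carbonyl carbon. Going by the values given here, no measured step bears on this particular change, and the single step in the set is unreadable, so no size or direction beyond the scatter can be projected from the data. Compound 3 is expected to sit at the limit as well, with the step that the limit leaves unreadable from compound 2 to compound 3 expected to be nil. The estimate for compound 3 is 50 ug/mL, in the range 35 ug/mL to 80 ug/mL, most likely reported only as a limit.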

Compound 3, half-maximal cytotoxic concentration: > 25 ug/mL
Compound 3: no number, only a limit; the forecaster's own chance of this, stated with the estimate: 85%; the middle value is on the limit's open side.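

Compound 3 gives > 25 ug/mL in this assay, a limit and not a number. With all three values being limits, the steps from compound 1 and from compound 2 to compound 3 cannot be read. The compounds shown leave open whether the group on the carbonyl carbon changes the concentration tolerated at all.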